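Carbonyl substituent change from compound 3 to compound 4

The source may hold more compounds than are shown below. What is called first, only, known or untested is meant among the compounds shown, and "the series" means these compounds.

Measured so far:
compound 1 `Fc1ccc(Nc2cc3[nH]c(Nc4cc(N5CCNCC5)ccn4)nc3cn2)cc1C(F)(F)F` gives 78%
compound 2 `Fc1ccc(Nc2cc3[nH]c(Nc4ccc(N5CCN(CC6CC6)CC5)cn4)nc3cn2)cc1C(F)(F)F` gives 41%
compound 3 `O=C(c1ccnc(Nc2nc3cnc(Nc4ccc(F)c(C(F)(F)F)c4)cc3[nH]2)c1)N1CCN(C2CC2)CC1` gives 93%

All three values come from an ADME assay on microsomes from liver (Mus musculus) for metabolic stability, read by LC-MS, using NADPH, with a stated time of 60 min, tested at 0.1 uM (on this read-out higher numbers stand for a more stable compound and lower numbers for a less stable compound), and compound 3 stands highest among them. Compound 1 is its nearest neighbour on the numbers, and compound 2 lies furthest away.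

Compound 4 `C[C@@H]1CN(C(=O)c2ccnc(Nc3nc4cnc(Nc5ccc(F)c(C(F)(F)F)c5)cc4[nH]3)c2)C[C@H](C)O1` has 2,6-dimethylmorpholin-4-yl in place of 4-cyclopropylpiperazin-1-yl on a carbonyl carbon and is otherwise the same as compound 3.

For the measured compounds named here, no measured step makes this exchange. The nearest evidence is a number 15 percentage points higher from compound 1 to compound 3 (beyond the scatter) with (4-cyclopropylpiperazin-1-yl)carbonyl in place of piperazin-1-yl on an aromatic carbon. Going by the values given here, that step is modest, though beyond the scatter, and it shows only that a compound with this carbonyl link can hold a high value. Compound 4 keeps the carbonyl, but what the new group does on it has not been tested. Compound 3 at 93% also leaves little room upward, so any expected movement leans downward.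

In this assay the estimate is a number 7 percentage points lower from compound 3 to compound 4 (within the scatter) and this small expected step is not thought to go beyond the scatter. For compound 4 the estimated value is 86% with an expected range from 62% to 98% as the likely span.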

Compound 4, percent of the compound remaining: 41%
Beside the measured number, compound 4's estimate is 45 percentage points above it, and the stated range ends above it.
By their numbers in this assay, from the lowest: compounds 2 and 4 (each within the scatter of the next); then compound 1; then compound 3.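

Working from this assay, the group on the carbonyl carbon turns out to carry much of the read-out: a number 52 percentage points lower from compound 3 to compound 4 (beyond the scatter) for 2,6-dimethylmorpholin-4-yl in place of 4-cyclopropylpiperazin-1-yl. For the compounds shown here, the carbonyl link alone therefore does not secure a high number, which the earlier compounds could not show. Replacing piperazin-1-yl on the aromatic carbon can go either way, with a number 15 percentage points higher from compound 1 to compound 3 (beyond the scatter) for (4-cyclopropylpiperazin-1-yl)carbonyl but a number 37 percentage points lower from compound 1 to compound 4 (beyond the scatter) for (2,6-dimethylmorpholin-4-yl)carbonyl, and nothing measured here says why these two groups part so widely.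

The exchange changes several things at once, so the compounds shown leave open whether the drop follows the ring oxygen, the two methyl groups, their defined stereocentres or the absence of the cyclopropyl ring. Plain morpholin-4-yl on the same carbonyl would separate the ring oxygen from the methyl groups, while unsubstituted piperazin-1-yl on that carbonyl would show how much of the high number depends on the cyclopropyl ring.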